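The compounds below may be only part of what the source reports. "The series", "measured", "known", "first", "only" and "open" are said of these compounds alone.

Working notes on the series. Compound 3 `COc1ccc(-c2cnc3nc(N)nc(N4CCN(C(=O)NCc5ccc(F)cc5)CC4)c3n2)cc1OC` gives 37 nM in a functional assay on cells (T-cell, Homo sapiens) for inhibition (a higher number here means a weaker inhibitor, a lower number a stronger inhibitor), the lowest of the three numbers recorded. Compound 1 `COc1ccc(-c2cnc3nc(N)nc(N4CCN(Cc5ccc(C(C)(C)C)cc5)CC4)c3n2)cc1OC` gives 4300 nM and compound 2 `COc1ccc(-c2cnc3nc(N)nc(N4CCN(Cc5c(Cl)cccc5Cl)CC4)c3n2)cc1OC` gives 7600 nM; the step of a 1.8-fold higher number from compound 1 to compound 2 (0.25 log units; within the scatter) lies within the scatter, so these two are read as equivalent.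

The next compound, compound 4 `COc1ccc(-c2cnc3nc(N)nc(N4CCN(c5ccccc5)CC4)c3n2)cc1OC`, differs from compound 3 as follows: phenyl in place of (4-fluorobenzyl)carbamoyl on an amine nitrogen in a ring.

For the measured compounds named here, two measured steps bear on this change, both ending at compound 3. The step of a 120-fold lower number from compound 1 to compound 3 (2.07 log units; beyond the scatter) and the step of a 210-fold lower number from compound 2 to compound 3 (2.31 log units; beyond the scatter) show that the (4-fluorobenzyl)carbamoyl group on the amine nitrogen in a ring sits on the strong side of a large gap, while the two benzyl groups sit on the weak side. Compound 4 keeps neither the carbamoyl nor a benzyl group on that nitrogen; it carries phenyl there directly. Going by the values given here, no measured compound holds this exact arrangement, so the expectation rests on the removal of the carbamoyl alone. A large increase in the number is therefore expected, roughly reversing the gains seen in a 120-fold lower number from compound 1 to compound 3 (2.07 log units; beyond the scatter) and a 210-fold lower number from compound 2 to compound 3 (2.31 log units; beyond the scatter), with wide uncertainty. The expected step is a 68-fold higher number from compound 3 to compound 4 (1.83 log units; beyond the scatter). Compound 4 is estimated at 2500 nM, with a range from 400 nM to 15000 nM.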

Compound 4, half-maximal inhibitory concentration: 400 nM
The estimate for compound 4 lay 6.3-fold (0.80 log units) above the measured number, within the range that was stated.
By their numbers in this assay, from the lowest: compound 3; then compound 4; then compounds 1 and 2 (each within the scatter of the next).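

In this assay, the amine nitrogen in a ring does not need a carbamoyl to sit well below the two benzyl compounds: phenyl, with 0 hydrogen-bond donors and 0 hydrogen-bond acceptors, gives an 11-fold lower number from compound 1 to compound 4 (1.03 log units; beyond the scatter) and also a 19-fold lower number from compound 2 to compound 4 (1.28 log units; beyond the scatter) at this position. The earlier split between the (4-fluorobenzyl)carbamoyl group and the two benzyl groups therefore does not describe the whole position, since phenyl falls at an intermediate level on both sides of the comparison. The (4-fluorobenzyl)carbamoyl group still keeps a large lead over phenyl, as an 11-fold higher number from compound 3 to compound 4 (1.03 log units; beyond the scatter) shows, so the smaller group does not carry all of its strength; no measurement here gives a reason for this order.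

The compounds shown leave open which part of the (4-fluorobenzyl)carbamoyl group accounts for its lead over phenyl, a question that an acetyl group or a phenylcarbamoyl group on the same nitrogen would address. They also leave open how far the phenyl result extends to a substituted ring such as 4-fluorophenyl or to a pyridyl ring attached directly at that nitrogen.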